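Adding a fluoro to the phenyl of compound 3

The source may hold more compounds than are shown below. What is called first, only, known or untested is meant among the compounds shown, and "the series" means these compounds.

Measured in a functional assay on K562 cells (Homo sapiens) for cytotoxicity, read by trypan blue exclusion, with a stated time of 96 h; on this read-out higher numbers stand for weaker inhibition and lower numbers for stronger inhibition:
compound 1 `COC(=O)CNc1cc(CS(=O)(=O)/C=C/c2c(OC)cc(OC)cc2OC)ccc1OC`: 100 nM
compound 2 `COC(=O)CCNc1cc(CS(=O)(=O)/C=C/c2c(OC)cc(OC)cc2OC)ccc1OC`: 1000 nM
compound 3 `COc1cc(OC)c(/C=C/S(=O)(=O)Cc2ccc(OC)c(NC(C(=O)O)c3ccccc3)c2)c(OC)c1`: 15 nM

Of these three, compound 3 holds the lowest number, and its steps to both of the others lie beyond the scatter. Compound 4 `COc1cc(OC)c(/C=C/S(=O)(=O)Cc2ccc(OC)c(NC(C(=O)O)c3ccc(F)cc3)c2)c(OC)c1` has not yet been measured. It differs from compound 3 in one place, where phenyl becomes 4-fluorophenyl: fluoro in place of hydrogen on an aromatic carbon. The fluoro sits on an aromatic carbon, para to a large group.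

Within the data shown here, all the measured steps alter the group on the nitrogen. They are a 10-fold higher number from compound 1 to compound 2 (1.00 log units; beyond the scatter), then a 6.7-fold lower number from compound 1 to compound 3 (0.82 log units; beyond the scatter), and the large 67-fold lower number from compound 2 to compound 3 (1.82 log units; beyond the scatter). They show that the read-out in this assay moves strongly when that group is replaced. Among the measured compounds shown here, none of them, however, places a substituent on the phenyl of compound 3, so the data offer no direct precedent for this change. The change itself is small beside those replacements, so no clear shift in either direction is expected. The expected result is no change at the digits printed from compound 3 to compound 4 (within the scatter), a step not expected to go beyond the scatter. For compound 4 the estimated value is 15 nM, with an expected range from 5 nM to 50 nM in this measurement.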

Compound 4, half-maximal inhibitory concentration: 80 nM
Compound 4: middle estimate off by 5.3-fold (0.73 log units), on the low side; measured number outside the range, above it.
By their numbers in this assay, from the lowest: compound 3; then compounds 4 and 1 (each within the scatter of the next); then compound 2.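

In this assay, the phenyl of compound 3 proves sensitive to substitution: with fluoro in place of hydrogen on an aromatic carbon, para to a large group, the read-out shows a 5.3-fold higher number from compound 3 to compound 4 (0.73 log units; beyond the scatter) and moves toward weaker inhibition. The earlier steps shown here all altered the whole group on the nitrogen, whereas this one shows that a single added fluoro, leaving the carboxy group and the rest of that group in place, is enough to go beyond the scatter. The change also narrows the standing of the carboxy(phenyl)methyl series, as carboxy(4-fluorophenyl)methyl gives a 1.3-fold lower number from compound 1 to compound 4 (0.10 log units; within the scatter) yet still keeps a large distance from the longer ester chain, with a 13-fold lower number from compound 2 to compound 4 (1.10 log units; beyond the scatter) in the same assay, and no evidence shown here explains the effect of the fluoro.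

The compounds shown leave open whether this shift belongs to fluoro alone or would also follow from chloro, methyl or methoxy at the same place. They also leave open whether a fluoro on another carbon of the phenyl would move the read-out as far.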